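Series notes: naphthalen-2-yl in place of 4-methoxyphenyl

This account rests on a few compounds, and the source may have more. Where it says the series, first, only, none or still open, it means among the compounds named here.

Measured compounds:
compound 1 `O=C1N=C(N2N=C(c3ccccc3)CC2c2ccc(Cl)cc2)S/C1=C1/C(=O)Nc2ccccc21`: 250 nM
compound 2 `COc1ccc(C2=NN(C3=NC(=O)/C(=C4\C(=O)Nc5ccccc54)S3)C(c3ccc(Cl)cc3)C2)cc1`: 100000 nM

Both compounds were read in a functional assay on cells (Cancer cell lines, Homo sapiens) for cytotoxicity, read by sulforhodamine B assay, with a stated time of 48 h; a lower number here means a stronger inhibitor of growth, a higher number a weaker inhibitor of growth. Compound 2 gives the highest number of the two; its nearest neighbour is compound 1, and the step of a 400-fold higher number from compound 1 to compound 2 (2.60 log units; beyond the scatter) is large and well beyond the scatter. Compound 3 `O=C1N=C(N2N=C(c3ccc4ccccc4c3)CC2c2ccc(Cl)cc2)S/C1=C1/C(=O)Nc2ccccc21` differs from compound 2 by naphthalen-2-yl in place of 4-methoxyphenyl on a carbon with a double bond to nitrogen. Among the compounds with values here, the one measured step that bears on this change is a 400-fold higher number from compound 1 to compound 2 (2.60 log units; beyond the scatter), where methoxy entered on an aromatic carbon and the number rose sharply; compound 3 lacks that methoxy, as compound 1 does, but carries naphthalen-2-yl, a group no measured compound has. A downward step of a size comparable to the measured one is therefore expected for a 100-fold lower number from compound 2 to compound 3 (2.00 log units; beyond the scatter), though the untested group widens the range. Compound 3 is estimated at 1000 nM, with a range from 150 nM to 20000 nM.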

Compound 3, concentration for 50% growth inhibition: 400 nM
For compound 3 the middle estimate is 2.5-fold (0.40 log units) above the measured one; measured number inside the range.
By their numbers in this assay, from the lowest: compounds 1 and 3 (each within the scatter of the next); then compound 2.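

In this assay the change to naphthalen-2-yl on the carbon with a double bond to nitrogen gives a 250-fold lower number from compound 2 to compound 3 (2.40 log units; beyond the scatter) and so recovers what compound 2 lost. The comparison with phenyl gives a 1.6-fold higher number from compound 1 to compound 3 (0.20 log units; within the scatter) and stays within the scatter, so a second six-membered aromatic ring at this position carries no loss, and among these three compounds only compound 2, with 4-methoxyphenyl, has the high number. Nothing available explains this difference.

Open, on these data alone, is whether the high number follows the methoxy itself or any group on that phenyl ring, which 4-methylphenyl or 4-aminophenyl at this carbon would help separate. As far as these compounds go, all three compounds also carry 4-chlorophenyl, so it is open whether the naphthalen-2-yl result holds with another group in its place.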